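A larger group on the triple bond of compound 3

The compounds below may be only part of what the source reports. "The series", "measured", "known", "first", "only" and "open" are said of these compounds alone.

In an ADME assay on HepG2 cells (Homo sapiens) for cytotoxicity (a higher number here means that more compound is tolerated, a lower number that less compound is tolerated), three compounds have been read so far. Compound 1 (`Fc1cccc(COc2ccc(Nc3ncnc4cc(C#CCN5CCNCC5)sc34)cc2Cl)c1`) gives > 29 uM as a limit of the assay and not a number. Compound 2 (`Fc1cccc(COc2ccc(Nc3ncnc4cc(C#CCN5CCCC5)sc34)cc2Cl)c1`) gives 4.9 uM as a true number. Compound 3 (`CC(C)CC#Cc1cc2ncnc(Nc3ccc(OCc4cccc(F)c4)c(Cl)c3)c2s1`) gives > 32 uM as a limit too, and not a number.

Compound 4 (`CC(C)(C)OC(=O)N1CCC[C@H]1C#Cc1cc2ncnc(Nc3ccc(OCc4cccc(F)c4)c(Cl)c3)c2s1`) keeps the core of compound 3 and changes one group (1-(tert-butoxycarbonyl)pyrrolidin-2-yl in place of isobutyl on a triple-bonded carbon). Among the measured compounds shown here, two measured steps bear on this change, both on the same chain. Pyrrolidin-1-yl in place of piperazin-1-yl gave an at least 5.9-fold lower number from compound 1 to compound 2 (0.77 log units; beyond the scatter) and isopropyl in place of pyrrolidin-1-yl gave an at least 6.5-fold higher number from compound 2 to compound 3 (0.81 log units; beyond the scatter) as the next move. For the measured compounds named here, both lie beyond the scatter, so the group at this place can matter, yet only one compound of the three gives a true number. Compound 4 also holds a five-membered non-aromatic ring, but with no net charge and on the triple-bonded carbon itself, so the reading of compound 2 at 4.9 uM is expected to carry over only loosely.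

In this assay the estimated change is an at least 1.4-fold lower number from compound 3 to compound 4 (0.16 log units; that floor lies within the scatter) and is expected to be small, perhaps hidden behind a limit again. For compound 4 the expected value is 22 uM with an estimated range from 7 uM to 60 uM in this reading.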

Compound 4, half-maximal toxic concentration: > 26 uM
Compound 4: only a limit was reported; the forecaster's own chance of this, stated with the estimate: 50%; middle value at least 1.1-fold (0.07 log units) away from the limit.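

In this assay compound 4 gives > 26 uM, a limit of the assay and not a number. Among the compounds shown here, the new point is that a far larger group on the triple-bonded carbon, 1-(tert-butoxycarbonyl)pyrrolidin-2-yl, with its five-membered non-aromatic ring and no net charge, still gives a compound that reaches a limit, and the one step that can be read is an at least 5.3-fold higher number from compound 2 to compound 4 (0.72 log units; beyond the scatter), so compound 2 remains the only one of the four with a true number. The steps to compound 4 from compound 3 and from compound 1 cannot be read, because both ends of each step are limits: the limit of > 26 uM in this assay, at which 1 of the 4 values shown sits.

As far as these compounds go, the true tolerated concentrations of compound 1, compound 3 and compound 4 remain unknown, so their order stays open, and so does any effect of the defined stereocentre in compound 4. From the compounds shown here alone, it is also open whether a free amine on the triple-bonded carbon, such as pyrrolidin-2-yl without its tert-butoxycarbonyl group, would give a reading closer to that of compound 2 or would stay at a limit.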